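A few compounds are considered here, and "the series" means these few. Any claim that something is new, unique, unknown or untested is made for them only; others in the source may bear on it.

Series notes. Compound 1 `COC(=O)[C@@]1(C)CCC=C2[C@@H]1CC[C@@H](C)[C@]2(C)Cc1c[nH]c2ccc(OC)cc12` is the reference point; in a functional assay on WiDr cells (Homo sapiens) for inhibition, read by sulforhodamine B assay, with a stated time of 48 h (a lower number here means a stronger inhibitor of growth, a higher number a weaker inhibitor of growth), compound 1 gives 5700 nM. Compound 2 `COC(=O)[C@@]1(C)CCC=C2[C@@H]1CC[C@@H](C)[C@]2(C)Cc1c[nH]c2ccc(C(F)(F)F)cc12` carries the change trifluoromethyl in place of methoxy on an aromatic carbon and in this assay compound 2 gives 18000 nM; the step is a 3.2-fold higher number from compound 1 to compound 2 (0.50 log units; beyond the scatter). Compound 3 `COC(=O)[C@@]1(C)CCC=C2[C@@H]1CC[C@@H](C)[C@]2(C)Cc1c(C)[nH]c2ccc(OC)cc12` differs from compound 1 by methyl in place of hydrogen on an aromatic carbon, and in this assay compound 3 gives 17000 nM, a step of a 3.0-fold higher number from compound 1 to compound 3 (0.47 log units; beyond the scatter). The numbers of compound 2 and compound 3 lie within the scatter of each other, so nothing separates them.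

Compound 4 `COC(=O)[C@@]1(C)CCC=C2[C@@H]1CC[C@@H](C)[C@]2(C)Cc1c(C)[nH]c2ccc(C(F)(F)F)cc12` is not yet measured. It differs from compound 3 by trifluoromethyl in place of methoxy on an aromatic carbon, which is the same change as that made from compound 1 to compound 2, at the same place, but now on the core of compound 3 rather than the core of compound 1; the two cores differ by methyl in place of hydrogen on an aromatic carbon. For the measured compounds named here, only one earlier instance of the change exists, so the expectation for compound 4 rests on that single step and on the value of compound 3. The step from compound 3 to compound 4 is expected to be about a 2.6-fold higher number from compound 3 to compound 4 (0.42 log units; beyond the scatter), comparable to a 3.2-fold higher number from compound 1 to compound 2 (0.50 log units; beyond the scatter). Compound 4 is therefore estimated at 45000 nM, with a range from 15000 nM to 130000 nM.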

Compound 4, concentration for 50% growth inhibition: 21000 nM
Estimate against measurement, compound 4: 2.1-fold (0.33 log units) above; measured number inside the range.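

In this assay, trifluoromethyl in place of methoxy gives a 1.2-fold higher number from compound 3 to compound 4 (0.09 log units; within the scatter), and methyl in place of hydrogen gives a 1.2-fold higher number from compound 2 to compound 4 (0.07 log units; within the scatter); both steps are small enough to sit within the scatter, unlike their earlier instances. Set beside its earlier instance, the change from methoxy to trifluoromethyl cannot be said to differ between the two cores: the same change on two cores in this assay, a 3.2-fold higher number (0.50 log units; beyond the scatter) from compound 1 to compound 2 and a 1.2-fold higher number (0.09 log units; within the scatter) from compound 3 to compound 4, 2.6-fold (0.41 log units) apart, within the scatter of two such steps The methyl change reads the same way, and with only one pair of steps for each change, the data show neither that a step carries over intact from one core to the other nor that it depends on the core: the same change on two cores in this assay, a 3.0-fold higher number (0.47 log units; beyond the scatter) from compound 1 to compound 3 and a 1.2-fold higher number (0.07 log units; within the scatter) from compound 2 to compound 4, 2.6-fold (0.41 log units) apart, within the scatter of two such steps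

Still open, as far as these compounds go, is whether an amine or a hydroxyl on the aromatic carbon that holds the methoxy or trifluoromethyl, or a longer chain in place of the added methyl, would shift the number in this assay. Also open, from the compounds shown here alone, is how a carboxylic acid or an amide in place of the methyl ester would read on either core.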